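The source may hold more compounds than are shown below. What is called first, only, known or untested is meant among the compounds shown, and "the series" means these compounds.

Compound 1, `Cn1nc(-c2ccccc2)nc1[S+](C)[O-]`, was tested in a functional assay on the whole organism for antagonist activity, with Mus musculus as the target; on this read-out lower numbers stand for an effect already at smaller amounts and higher numbers for an effect only at larger amounts of compound. In this assay compound 1 reached only the limit of > 200 mg/kg, a limit rather than a number. Compound 2, `Cn1nc(-c2ccccc2)nc1S(C)(=O)=O`, is the same core carrying a group of 4 heavy atoms in place of the group of 3 heavy atoms on an aromatic carbon. In this assay compound 2 also gave only the limit of > 200 mg/kg, again a limit and not a number. The step that the two limits leave unreadable from compound 1 to compound 2 therefore cannot be read, since (the limit of > 200 mg/kg in this assay, at which 2 of the 2 values shown sit). Compound 2 thus stands at the edge of what this assay reports, with no measured value beside it.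

Compound 3, `Cn1nc(-c2cccc(F)c2)nc1S(C)(=O)=O`, differs from compound 2 by a single change: fluoro in place of hydrogen on an aromatic carbon. For the measured compounds named here, the only measured step, from compound 1 to compound 2, bears on compound 3 merely by showing both neighbours at the limit; its size is not readable, so no direction can be taken from it.

Compound 3 is therefore expected to remain at or near the limit, estimated at 300 mg/kg, within 100 mg/kg to 1000 mg/kg.

The step from compound 2 to compound 3 is estimated as a step that the limit leaves unreadable from compound 2 to compound 3, not beyond the scatter.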

Compound 3, dose for half-maximal effect: > 100 mg/kg
Compound 3: a limit, no number; the forecaster's own chance of this, stated with the estimate: 80%; the middle value does not contradict the limit.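

In this assay, for the compounds shown here, compound 3 gave only > 100 mg/kg, a limit and not a number, so no step from compound 2 to compound 3 can be read. The compounds shown leave open what fluoro in place of hydrogen does to the read-out, and whether any change on the shared core gives a readable value in this assay.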